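The compounds below may be only part of what the source reports. "The series", "measured", "known", "first", "only" and "open" are said of these compounds alone.

Among the measured compounds shown here, in an ADME assay on Caco-2 cells (Homo sapiens) for permeability (on this read-out lower numbers stand for lower permeability and higher numbers for higher permeability), compound 1 `Cc1cc(CC(OC(=O)N2CCC(c3cc4ccccc4[nH]c3=O)CC2)c2cc(CN3CCCCC3)ccn2)cc2cn[nH]c12` gives 85 nm/s as the only true number so far. Compound 2 `Cc1cc(CC(OC(=O)N2CCC(N3CCc4ccccc4NC3=O)CC2)c2cc(C(=O)N(C)C)cc(Cl)n2)cc2cn[nH]c12` stands at < 15 nm/s as a limit and not a number. Compound 3 `Cc1cc(CC(OC(=O)N2CCC(c3cc4ccccc4[nH]c3=O)CC2)c2cc(CN3CCCCCC3)ccn2)cc2cn[nH]c12` differs from compound 1 in one place, with azepan-1-yl in place of piperidin-1-yl on a saturated chain carbon bound to an aromatic carbon, and azepan-1-yl in place of piperidin-1-yl on a saturated chain carbon bound to an aromatic carbon gives the count of that change. For the measured compounds named here, no measured pair speaks to this change, so a 1.1-fold lower number from compound 1 to compound 3 (0.03 log units; within the scatter) is expected to stay within the scatter of this assay in either direction. For compound 3 the estimate is 80 nm/s with an expected range from 35 nm/s to 170 nm/s as the likely span.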

Compound 3, apparent permeability: 28 nm/s
Estimate against measurement, compound 3: 2.9-fold (0.46 log units) above; measured number outside the range, below it.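

In this assay, azepan-1-yl in place of piperidin-1-yl on a saturated chain carbon bound to an aromatic carbon gives a 3.0-fold lower number from compound 1 to compound 3 (0.48 log units; beyond the scatter). This first pair at this place shows that the read-out responds to this change of ring. Compound 2 alone sits at a limit of the assay, not a number: the limit of < 15 nm/s in this assay, at which 1 of the 3 values shown sits.

This single pair gives no trend with ring size. On these data alone, how a pyrrolidin-1-yl or morpholin-4-yl group at this place would compare with piperidin-1-yl remains open, as does whether the step carries over to other cores.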